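Side chain trimming in an anticonvulsant succinimide series

A few compounds are considered here, and "the series" means these few. Any claim that something is new, unique, unknown or untested is made for them only; others in the source may bear on it.

Measured so far:
compound 1 `COCC(C(=O)N1CCN(c2cccc(C(F)(F)F)c2)CC1)N1C(=O)CCC1=O` — 85.1 mg/kg
compound 2 `CCC(C(=O)N1CCN(c2cccc(C(F)(F)F)c2)CC1)N1C(=O)CCC1=O` — 91.7 mg/kg

In a functional assay on the whole organism (strain Swiss) with Mus musculus as the target, in the maximal electroshock model, with a stated time of 0.5 h (a lower number here means that less compound is needed, a higher number that more compound is needed for the effect), compound 2 gives the highest of the two numbers, though the step of a 1.1-fold higher number from compound 1 to compound 2 (0.03 log units; within the scatter) lies within the scatter, so the two stand level. Compound 3 `CC(C(=O)N1CCN(c2cccc(C(F)(F)F)c2)CC1)N1C(=O)CCC1=O` differs from compound 2 by hydrogen in place of methyl on a saturated chain carbon, two bonds along the chain from an amide-type nitrogen in a ring and a carbonyl carbon. Going by the values given here, the one measured step, from methoxy to methyl at that same carbon, was flat, and no step for the further cut to hydrogen has been measured. A step of a 1.0-fold lower number from compound 2 to compound 3 (0.01 log units; within the scatter) is therefore expected, nothing beyond the scatter. For compound 3 the estimate in this assay is 90 mg/kg, with a range from 45 mg/kg to 180 mg/kg.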

Compound 3, dose for half-maximal effect: 88.4 mg/kg
For compound 3 the middle estimate is 1.0-fold (0.01 log units) above the measured one; the range from low to high includes it.
By their numbers in this assay, from the lowest: compounds 1, 3 and 2 (each within the scatter of the next).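

In this assay, hydrogen at this saturated chain carbon holds the level set by the larger groups: the step is a 1.0-fold lower number from compound 2 to compound 3 (0.02 log units; within the scatter), and against methoxy it is a 1.0-fold higher number from compound 1 to compound 3 (0.02 log units; within the scatter). Among these three compounds, neither methyl nor methoxy at this position is required to hold that level, so the position has so far shown no sensitivity to the substituent. No supporting data bear on this flat result. Still open, from the compounds shown here alone, is whether a longer chain, a phenyl ring or an amine at this carbon would give a step beyond the scatter. The two stereo forms at this carbon also remain unresolved in the compounds shown.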